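One Aryl Group Exchanged on a Shared Core

A few compounds are considered here, and "the series" means these few. Any claim that something is new, unique, unknown or untested is made for them only; others in the source may bear on it.

In a functional assay on DU-145 cells (Homo sapiens) for inhibition, read by trypan blue exclusion, with a stated time of 96 h (on this read-out lower numbers stand for stronger inhibition of growth and higher numbers for weaker inhibition of growth), compound 1 (`CC(=O)Nc1ccc(/C=C(/SCc2ccc(F)cc2)C(=O)c2ccc(C(=O)O)cc2)cc1[N+](=O)[O-]`) gives 10000 nM. Compound 2 (`CN(C)c1ccc(/C=C(/SCc2ccc(F)cc2)C(=O)c2ccc(C(=O)O)cc2)cc1`) gives 10000 nM, which places it level with compound 1, with no difference beyond the scatter. Compound 3 (`O=C(O)c1ccc(C(=O)/C(=C\c2ccc(O)c([N+](=O)[O-])c2)SCc2ccc(F)cc2)cc1`) has not yet been measured in this assay. It departs from compound 2 in one place: 4-hydroxy-3-nitrophenyl in place of 4-(dimethylamino)phenyl on a double-bonded chain carbon bound to a double-bonded chain carbon. In words, 4-hydroxy-3-nitrophenyl stands in place of 4-(dimethylamino)phenyl on a double-bonded chain carbon bound to a double-bonded chain carbon. Going by the values given here, no step between measured compounds exists to gauge this exchange, so the expectation rests on only two values. Those values show no spread, with compound 1 at 10000 nM and compound 2 at 10000 nM. On that basis, no step beyond the scatter is expected in this assay, and no firm direction can be assigned. The estimated change is small, a 1.3-fold lower number from compound 2 to compound 3 (0.10 log units; within the scatter), and it is expected to remain within the scatter. For compound 3 the estimated value is 8000 nM, with an expected range from 3000 nM to 20000 nM.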

Compound 3, concentration for 50% growth inhibition: > 100000 nM
Compound 3 gave a limit, no number; the forecaster's own chance of this, stated with the estimate: 25%; middle value at least 12-fold (1.09 log units) away from the limit.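

Among the earlier compounds, the aryl group on a double-bonded chain carbon bound to a double-bonded chain carbon had shown no effect in this assay, since compound 1 and compound 2 stood level. The exchange of 4-(dimethylamino)phenyl for 4-hydroxy-3-nitrophenyl now shows that this place can respond strongly, giving an at least 10-fold higher number from compound 2 to compound 3 (1.00 log units; beyond the scatter), and hydroxy in place of acetamido on an aromatic carbon, with the nitro group present on both sides, gives an at least 10-fold higher number from compound 1 to compound 3 (1.00 log units; beyond the scatter). The full size of both steps stays open, as compound 3 gave a limit and not a number: the limit of > 100000 nM in this assay, at which 1 of the 3 values shown sits.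

The compounds shown leave open whether a methoxy group or a free amine in place of the hydroxy would stay at the limit of compound 3 or return to the level of compound 1. They also leave open whether the same step would appear with a methyl ester or a primary amide in place of the carboxylic acid that all three compounds share.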